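This account rests on a few compounds, and the source may have more. Where it says the series, first, only, none or still open, it means among the compounds named here.

Working notes on the series. Compound 1 `O=c1[nH]c(-c2cccc3ccccc23)nc2ccc(N3CCCCC3)cc12` and compound 2 `CCN(CC)c1ccc2nc(-c3cccc4ccccc34)[nH]c(=O)c2c1` share one core and differ only in the amine on the aromatic carbon. Among the measured compounds shown here, in a functional assay on HeLa cells (Homo sapiens) for cytotoxicity, read by MTT assay, with a stated time of 2 days (on this read-out lower numbers stand for stronger inhibition and higher numbers for weaker inhibition), compound 1 gives 330 nM, and compound 2 gives 4 nM; the step of an 83-fold lower number from compound 1 to compound 2 (1.92 log units; beyond the scatter) is the only measured step between paired compounds in the set.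

Compound 3 `Cc1ccc2nc(-c3cccc(OC(F)(F)F)c3)[nH]c(=O)c2c1` carries a different substituent pattern on the shared core. In this assay compound 3 returns only a limit, > 50000 nM, which is the limit of > 50000 nM in this assay, at which 1 of the 3 values shown sits; compound 3 therefore stands at the weakest end of the numbers shown, with no finite value of its own.

Compound 4 `Cc1ccc2nc(-c3cccc(F)c3)[nH]c(=O)c2c1` is the next member. It differs from compound 3 by fluoro in place of trifluoromethoxy on an aromatic carbon. For the measured compounds named here, no measured step touches this position: the one measured step concerns the amine of compound 1 and compound 2, not the group changed here, so it gives no direction for the step from compound 3 to compound 4. With compound 3 at the limit > 50000 nM, compound 4 is expected to sit at or near the same limit, so the step of a number no higher from compound 3 to compound 4 (the limit leaves the size open) is expected to be none beyond the scatter. The estimate for compound 4 in this assay is 50000 nM, within 10000 nM to 200000 nM.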

Compound 4, half-maximal inhibitory concentration: > 50000 nM
Compound 4: a limit, no number; the forecaster's own chance of this, stated with the estimate: 75%; the middle value lies on the limit itself.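

Compound 3 and compound 4 both return only a limit, so no step can be read between them and the change from trifluoromethoxy to fluoro remains unreadable: the limit of > 50000 nM in this assay, at which 2 of the 4 values shown sit.

The compounds shown leave open how trifluoromethoxy and fluoro compare at this position when neither compound sits at a limit.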